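Methoxyphenyl position on the shared oxazole-bearing series

A few compounds are considered here, and "the series" means these few. Any claim that something is new, unique, unknown or untested is made for them only; others in the source may bear on it.

Working notes on the series. In an assay on cells for antagonist activity at vitamin D3 receptor (Homo sapiens), read by a luciferase reporter (on this read-out lower numbers stand for stronger inhibition and higher numbers for weaker inhibition), compound 1 `COC(=O)CCc1ccc(OCc2oc(-c3cccc(OC)c3)nc2C)cc1` gives 6700 nM. Compound 2 `COc1ccccc1-c1nc(C)c(COc2ccc(CCC(=O)O)cc2)o1` carries the same acid-bearing chain on the shared core but with the methoxy group at a different ring position. In this assay compound 2 gives > 100000 nM, which is a limit of the assay and not a number; compound 2 thus stands at the limit of > 100000 nM in this assay, at which 1 of the 2 values shown sits, the weaker end of what the assay reports.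

Compound 3 `COc1cccc(-c2nc(C)c(COc3ccc(CCC(=O)O)cc3)o2)c1` differs from compound 2 in one place: 3-methoxyphenyl in place of 2-methoxyphenyl on an aromatic carbon. Among the compounds with values here, no measured pair in the set shows this change directly, so its size cannot be read from the data. Because compound 2 sits at the limit of > 100000 nM in this assay, at which 1 of the 2 values shown sits, the step can only point toward stronger inhibition or stay beyond the scatter in no measurable direction. The expectation is a step of an at least 5.0-fold lower number from compound 2 to compound 3 (0.69 log units; beyond the scatter) from compound 2 to compound 3, toward a lower number. Compound 3 is estimated at 20000 nM in this assay, with a range from 3000 nM to 100000 nM.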

Compound 3, half-maximal inhibitory concentration in the vitamin D3 receptor assay: 26700 nM
Compound 3: the middle estimate sits 1.3-fold (0.13 log units) below what was measured; low and high end bracket the measured number.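

In the vitamin D3 receptor assay, 3-methoxyphenyl in place of 2-methoxyphenyl on the shared core brings the acid-bearing series onto a measurable number, a change shown by an at least 3.7-fold lower number from compound 2 to compound 3 (0.57 log units; beyond the scatter). In the vitamin D3 receptor assay compound 2 gives > 100000 nM, which is a limit and not a number, so this step gives only a bound on the size of the positional change and not the size itself: the limit of > 100000 nM in the vitamin D3 receptor assay, at which 1 of the 3 values shown sits.

With 3-methoxyphenyl held fixed, the earlier ester can now be set against the acid, and in the vitamin D3 receptor assay hydrogen in place of methyl on an oxygen next to a carbonyl group gives a 4.0-fold higher number from compound 1 to compound 3 (0.60 log units; beyond the scatter), while in a physicochemical assay for solubility, tested at 500 uM (a higher number here means a more soluble compound, a lower number a less soluble compound), the positional change stays within the scatter, with a 1.7-fold lower number from compound 2 to compound 3 (0.23 log units; within the scatter). In the physicochemical assay compound 2 gives 400000 nM and compound 3 gives 234000 nM.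

As far as these compounds go, how far compound 2 lies past its limit stays open, as does whether the step from methyl to hydrogen would run the same way with 2-methoxyphenyl in place. The compounds shown also leave open what an amine or a longer chain in place of the methoxy group would do to the number in the vitamin D3 receptor assay.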